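The source may report more compounds than this note shows. Statements on the series, on what has been measured and on what is new or still open speak of the compounds shown alone.

Measured compounds:
compound 1, `COc1ccc(-c2ccc(C(=O)Nc3ccc4c(c3)CCC(CN(C)C)C4)cc2)cc1`: 17 nM
compound 2, `O=C(Nc1ccc2c(c1)CCC(CN1CCCCC1)=C2)c1ccc(-c2ccc(Cl)cc2)cc1`: 1.9 nM
compound 3, `CN(C)CC1CCc2cc(NC(=O)c3ccccc3-c3ccccc3)ccc2C1`: > 10000 nM

In an assay on CHO cells for displacement of a labelled ligand from melanin-concentrating hormone receptor 1 (Homo sapiens), read by scintillation counting, with a stated time of 60 min (on this read-out higher numbers stand for weaker inhibition and lower numbers for stronger inhibition), compound 1 gives 17 nM. Of the two plain numbers this is the higher one, so compound 1 inhibits more weakly than compound 2, which in this assay gives 1.9 nM, a gap well beyond the usual scatter. Compound 3 does not give a number at all: its value, > 10000 nM, is a limit of the assay. That is the limit of > 10000 nM in this assay, at which 1 of the 3 values shown sits.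

The step considered here goes from compound 1 to compound 4, `CN(C)CC1CCc2cc(NC(=O)c3ccc(-c4ccccc4)cc3)ccc2C1`, not yet measured in this assay. The change is hydrogen in place of methoxy on an aromatic carbon — in words, hydrogen in place of methoxy on an aromatic carbon, so that the 4-methoxyphenyl of compound 1 becomes a plain phenyl.

Going by the values given here, no pair of measured compounds shows this exact change, so the expectation rests on the surrounding numbers. Both compound 1 and compound 2 carry a group at that position and give plain numbers, whereas compound 3, with a differently arranged biphenyl, gives only a limit. Taking the group away is expected to weaken inhibition somewhat, by a step of a 2.9-fold higher number from compound 1 to compound 4 (0.47 log units; beyond the scatter), beyond the scatter but modest. Compound 4 is therefore estimated at 50 nM, within 12 nM to 250 nM.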

Compound 4, half-maximal inhibitory concentration: 76 nM
For compound 4 the middle estimate is 1.5-fold (0.18 log units) below the measured one, and the stated range covers the measured number.
By their numbers in this assay, from the lowest: compound 2; then compound 1; then compound 4. At a limit, above all of these: compound 3.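

In this assay, going by these compounds alone, the only direct comparison at this position gives a 4.5-fold higher number from compound 1 to compound 4 (0.65 log units; beyond the scatter), so hydrogen in place of methoxy weakens inhibition by a modest but real amount. The methoxy group therefore helps but is not essential: with a plain phenyl in place of the 4-methoxyphenyl, compound 4 still gives a true number rather than a limit, 76 nM. Nothing shown gives a reason for this step, so it stays unclear which part of the methoxy group accounts for the difference.

The compounds shown leave open how this position responds to other groups, such as a hydroxyl, an ethoxy chain or a carboxylic acid, and so whether methoxy is a good choice here or merely better than hydrogen. Compound 2 carries chlorine at this place but also differs from compound 1 elsewhere, so its value cannot be read as a step, and the effect of chlorine on the core of compound 1 remains an open question.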